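This account rests on a few compounds, and the source may have more. Where it says the series, first, only, none or still open, it means among the compounds named here.

In a functional assay on A-375 cells (Homo sapiens) for activation, with a stated time of 3 days (on this read-out higher numbers stand for an effect only at larger amounts of compound and lower numbers for an effect already at smaller amounts), three compounds have been measured so far. Compound 1 `O=C(Nc1ccc(-c2cscn2)cc1)C1CCN(Cc2ccc(F)c(F)c2)CC1` gives 19000 nM. Compound 2 `O=C(Nc1ccc(-c2cscn2)cc1)C1CCCN(Cc2cccnc2)C1` is reported only as a limit of the assay, > 20000 nM. Compound 3 `O=C(Nc1ccc(-c2nccs2)cc1)C1CCCN(Cc2ccc(F)c(F)c2)C1` gives 800 nM, the lowest of the two actual numbers, and its gap to compound 1, the nearest number, lies beyond the usual scatter of repeated measurements.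

Compound 4 `O=C(Nc1ccc(-c2ccco2)cc1)C1CCCN(Cc2ccc(F)c(F)c2)C1` is the next one to follow. It differs from compound 3 in a single group: furan-2-yl in place of 1,3-thiazol-2-yl on an aromatic carbon. In words, this is furan-2-yl in place of 1,3-thiazol-2-yl on an aromatic carbon, para to a large group. Among the measured compounds shown here, no measured pair of compounds shows this exchange, so any forecast has to start from compound 3 at 800 nM. Only a small rise in the number is expected, one that stays within the scatter: the estimated step is a 1.5-fold higher number from compound 3 to compound 4 (0.18 log units; within the scatter). For compound 4 the estimated value is 1200 nM, with an expected range from 350 nM to 4500 nM.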

Compound 4, half-maximal effective concentration: 2200 nM
Compound 4: the middle estimate sits 1.8-fold (0.26 log units) below what was measured, and the stated range covers the measured number.
By their numbers in this assay, from the lowest: compound 3; then compound 4; then compound 1. At a limit, above all of these: compound 2.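

In this assay, the group on this aromatic carbon, para to a large group, affects the read-out: with the rest of the molecule unchanged, furan-2-yl in place of 1,3-thiazol-2-yl gives a 2.8-fold higher number from compound 3 to compound 4 (0.44 log units; beyond the scatter). Among the compounds shown here, the earlier compounds included no pair differing in this place alone, so this is the first direct reading of a change here, and it shows that two five-membered aromatic rings of 5 heavy atoms each are not interchangeable in this assay. Nothing measured here explains the size of this step.

Going by these compounds, whether a five-membered ring is needed at this position remains open, and a phenyl ring, a nitrile or an amine there would help to test that. For the compounds shown here, only this one pair shows the exchange, and whether the step would carry over to another core also remains unknown.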